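The source may report more compounds than this note shows. Statements on the series, on what has been measured and on what is new or still open speak of the compounds shown alone.

Compound 1 `CCCc1nn(C)c2c(NC3CC3)nc(/C=C/c3ccc[n+]([O-])c3)nc12` gives 580000 nM in a functional assay on L02 cells (Homo sapiens) for inhibition, read by Griess assay, with stated times of 1 h and 24 h; on this read-out lower numbers stand for stronger inhibition and higher numbers for weaker inhibition.
Compound 2 `COc1cc(/C=C/c2nc(N3CCCC3)c3sccc3n2)cc(OC)c1OC` gives 681000 nM in this assay.

Among the measured compounds shown here, only two compounds have been measured, and both are weak inhibitors. Compound 2 has the highest of the two numbers; its nearest neighbour is compound 1, whose number lies within the usual scatter of this kind of measurement, so the two cannot be told apart on these data.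

Compound 3 `COc1ccc(Nc2nc(/C=C/c3cc(OC)c(OC)c(OC)c3)nc3ccsc23)cc1` has not yet been measured. It differs from compound 2 in one place: (4-methoxyphenyl)amino in place of pyrrolidin-1-yl on an aromatic carbon. For the measured compounds named here, no pair of measured compounds shows what such an exchange does, so there is no measured step to lean on. Given that compound 2 sits at 681000 nM and that nothing in the two measured values points one way or the other, the expected step from compound 2 to compound 3 is a 1.4-fold lower number from compound 2 to compound 3 (0.13 log units; within the scatter), which is no larger than the scatter.

On that basis compound 3 is estimated to give 500000 nM in this assay, with a range from 150000 nM to 1500000 nM.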

Compound 3, half-maximal inhibitory concentration: 279000 nM
The estimate for compound 3 lay 1.8-fold (0.25 log units) above the measured number; the measured number falls inside the stated range.
By their numbers in this assay, from the lowest: compound 3; then compounds 1 and 2 (each within the scatter of the next).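

Placing (4-methoxyphenyl)amino in place of pyrrolidin-1-yl on an aromatic carbon next to the ring nitrogen gives, in this assay, a 2.4-fold lower number from compound 2 to compound 3 (0.39 log units; beyond the scatter), the first difference among these compounds that lies beyond the scatter. This position is therefore not silent: the group attached there can shift the number, and the exchange for a six-membered aromatic ring carrying a hydrogen-bond donor brings no loss, although the step is modest and compound 3 remains a weak inhibitor at 279000 nM in this read-out. No separate measurement bears on why the number moved, and this single exchange alters the ring type, the heavy-atom count and the hydrogen-bond donors all at once.

On these data alone, it remains open which part of the entering group carries the step, a question that plain phenylamino without the methoxy, or the methoxy moved elsewhere on the ring, could help to separate. It is also unknown how a non-aromatic amine with a free hydrogen, such as cyclohexylamino, or a morpholine ring would behave at this same position on the same core.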